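Pyridinylmethyl phthalazine piperazine amides: anilide exchange

The compounds below may be only part of what the source reports. "The series", "measured", "known", "first", "only" and "open" are said of these compounds alone.

Compound 2 `O=C(CN1CCN(c2nnc(Cc3ccccc3)c3ccccc23)CC1)Nc1cc(C(F)(F)F)ccc1Cl` gives 19500 nM in a functional assay on MDA-MB-231 cells (Homo sapiens) for cytotoxicity, read by MTT assay, with a stated time of 72 h; a higher number here means a weaker inhibitor, a lower number a stronger inhibitor; compound 1 `O=C(CN1CCN(c2nnc(Cc3ccccc3)c3ccccc23)CC1)Nc1c(F)cccc1F` gives 5490 nM in this assay. The step of a 3.6-fold lower number from compound 2 to compound 1 (0.55 log units; beyond the scatter) comes from 2,6-difluorophenyl in place of 2-chloro-5-(trifluoromethyl)phenyl on an amide-type nitrogen. Compound 3 `O=C(CN1CCN(c2nnc(Cc3ccncc3)c3ccccc23)CC1)Nc1cc(C(F)(F)F)ccc1Cl` gives 3.7 nM in this assay, a step of a 5300-fold lower number from compound 2 to compound 3 (3.72 log units; beyond the scatter) that comes from pyridin-4-yl in place of phenyl on a saturated chain carbon bound to an aromatic carbon; compound 3 carries the lowest number among the three measured compounds. Compound 4 `O=C(CN1CCN(c2nnc(Cc3ccncc3)c3ccccc23)CC1)Nc1c(F)cccc1F` is not yet measured; it differs from compound 3 by 2,6-difluorophenyl in place of 2-chloro-5-(trifluoromethyl)phenyl on an amide-type nitrogen, the same change as from compound 2 to compound 1, made at the same place on an amide-type nitrogen. Because the earlier step was a 3.6-fold lower number from compound 2 to compound 1 (0.55 log units; beyond the scatter), a step of similar size is expected here, with the caution that the change is seen only once and the two cores differ by pyridin-4-yl in place of phenyl on a saturated chain carbon bound to an aromatic carbon, so the effects need not add simply; the expected step is a 2.5-fold lower number from compound 3 to compound 4 (0.39 log units; beyond the scatter). Compound 4 is estimated at 1.5 nM, most likely between 0.3 nM and 10 nM in this assay.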

Compound 4, half-maximal inhibitory concentration: 1900 nM
The estimate for compound 4 lay 1300-fold (3.10 log units) below the measured number; measured number outside the range, above it.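

On the core of compound 3, 2,6-difluorophenyl in place of 2-chloro-5-(trifluoromethyl)phenyl gives a 510-fold higher number from compound 3 to compound 4 (2.71 log units; beyond the scatter) in this assay, the opposite direction to the step on the core of compound 2, so this amide-side change does not carry between the two cores: the same change on two cores in this assay, a 3.6-fold lower number (0.55 log units; beyond the scatter) from compound 2 to compound 1 and a 510-fold higher number (2.71 log units; beyond the scatter) from compound 3 to compound 4, 1800-fold (3.26 log units) apart, beyond the scatter of two such steps

Pyridin-4-yl in place of phenyl gives only a 2.9-fold lower number from compound 1 to compound 4 (0.46 log units; beyond the scatter) with the 2,6-difluorophenyl amide, far smaller than its step with the other amide: the same change on two cores in this assay, a 5300-fold lower number (3.72 log units; beyond the scatter) from compound 2 to compound 3 and a 2.9-fold lower number (0.46 log units; beyond the scatter) from compound 1 to compound 4, 1800-fold (3.26 log units) apart, beyond the scatter of two such steps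

The two changes therefore do not add across these compounds, but four compounds cannot show which part of either group sets this dependence or how far it extends.

From the compounds shown here alone, it remains open whether the low number of compound 3 needs both chlorine and trifluoromethyl on the phenyl ring, or whether either alone would suffice. Also open, going by these compounds, is whether a pyridin-3-yl group would pair with these amides as pyridin-4-yl does.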